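Pyridin-3-yl for pyridin-4-yl on the amide-bearing arm

The source may report more compounds than this note shows. Statements on the series, on what has been measured and on what is new or still open speak of the compounds shown alone.

The series rests on a shared core, seen in compound 1 `CCCn1c(SCc2cc([N+](=O)[O-])ccc2OC)nc2cc(NC(=O)NC(C)(C)C)cc(C(=O)NC)c21` and compound 2 `CCCn1c(SCc2cc([N+](=O)[O-])ccc2OC)nc2cc(NC(=O)NC(C)(C)C)cc(C(=O)NCc3ccncc3)c21`, and is read in an assay on isolated protein for inhibition of Gonadotropin-releasing hormone receptor (Homo sapiens); on this read-out lower numbers stand for stronger inhibition and higher numbers for weaker inhibition. Compound 1 gives 41 nM, and compound 2 gives 61 nM. Within the data shown here, the one measured step, a 1.5-fold higher number from compound 1 to compound 2 (0.17 log units; within the scatter), separates the two, so compound 2 stands as the higher of the two numbers, with compound 1 as its only neighbour and within the scatter of it. Compound 3 `CCCn1c(SCc2cc([N+](=O)[O-])ccc2OC)nc2cc(NC(=O)NC(C)(C)C)cc(C(=O)NCc3cccnc3)c21` is not yet measured. It differs from compound 2 by pyridin-3-yl in place of pyridin-4-yl on a saturated chain carbon bound to an amide-type nitrogen. Among the measured compounds shown here, no measured pair shows this exact change; the only step that bears on the region is a 1.5-fold higher number from compound 1 to compound 2 (0.17 log units; within the scatter), which tells that attaching pyridin-4-yl to that saturated chain carbon moved the number by little. Since the two structures hold the same atoms joined differently, and since the earlier step at this position stayed within the scatter, compound 3 is expected to show a step of a 1.0-fold lower number from compound 2 to compound 3 (0.01 log units; within the scatter), no change beyond the scatter in either direction. Compound 3 is therefore estimated at 60 nM, with a range from 25 nM to 150 nM.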

Compound 3, half-maximal inhibitory concentration: 69 nM
Estimate against measurement, compound 3: 1.2-fold (0.06 log units) below; measured number inside the range.
By their numbers in this assay, from the lowest: compounds 1, 2 and 3 (each within the scatter of the next).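

In this assay, pyridin-3-yl in place of pyridin-4-yl on the saturated chain carbon bound to an amide-type nitrogen gives a 1.1-fold higher number from compound 2 to compound 3 (0.05 log units; within the scatter), so this position does not separate the two pyridine attachments, a point that compound 2 alone could not show. Against hydrogen at the same carbon, pyridin-3-yl gives a 1.7-fold higher number from compound 1 to compound 3 (0.23 log units; within the scatter), so a second ring at this place also stays within the scatter, and the position now accepts hydrogen, pyridin-4-yl and pyridin-3-yl with no step that can be told apart from repeat measurement. The data offer no explanation for how closely these numbers sit.

The three compounds carry only hydrogen or a pyridinyl group at this carbon, which leaves open whether pyridin-2-yl, a plain phenyl ring, an amine or a carboxylic acid there would also stay within the scatter. On these data alone, it also remains open whether a longer chain between the amide-type nitrogen and the ring would give a step beyond the scatter.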